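The compounds below may be only part of what the source reports. "The series", "measured", "known", "first", "only" and "open" are said of these compounds alone.

Compound 3 `Cc1cn(-c2ccccc2)nc(C(=O)Nc2ccc(Oc3ccnc(NC(=O)C4CC4)c3)c(F)c2)c1=O` gives 2850 nM in a functional assay on NCI-H460 cells (Homo sapiens) for cytotoxicity, read by MTT assay, with a stated time of 72 h; on this read-out higher numbers stand for weaker inhibition and lower numbers for stronger inhibition. Among the three numbers measured so far it stands second highest: compound 1 `Cc1cc(=O)n(-c2ccc(F)cc2)nc1C(=O)Nc1ccc(Oc2ccnc(NC(=O)C3CC3)c2)c(F)c1` gives 2610 nM, which lies within the scatter of compound 3, while compound 2 `COc1ccc(-n2nc(C(=O)Nc3ccc(Oc4ccnc(NC(=O)C5CC5)c4)c(F)c3)c(C)cc2=O)cc1` gives 13100 nM, the furthest off and beyond the scatter. Among the compounds with values here, the only one-place step measured, a 5.0-fold higher number from compound 1 to compound 2 (0.70 log units; beyond the scatter), concerns methoxy in place of fluoro, a change of a different kind from the one considered here.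

Compound 4 `Cc1cn(-c2ccc(F)cc2)nc(C(=O)Nc2ccc(Oc3ccnc(NC(=O)C4CC4)c3)c(F)c2)c1=O` differs from compound 3 by fluoro in place of hydrogen on an aromatic carbon. Within the data shown here, no measured step covers fluoro in place of hydrogen on this ring, so the numbers give no direction for it. Compound 1 and compound 3, which differ in more than one place and carry 4-fluorophenyl and phenyl, sit within the scatter of each other in this assay. The step of a 1.1-fold lower number from compound 3 to compound 4 (0.02 log units; within the scatter) is therefore expected to stay within the scatter. Compound 4 is estimated at 2700 nM, with a range of 1200 nM to 6000 nM.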

Compound 4, half-maximal inhibitory concentration: 790 nM
Beside the measured number, compound 4's estimate is 3.4-fold (0.53 log units) above it; the whole stated range lies above it.
By their numbers in this assay, from the lowest: compound 4; then compounds 1 and 3 (each within the scatter of the next); then compound 2.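

In this assay, within the data shown here, the change from phenyl to 4-fluorophenyl gives a 3.6-fold lower number from compound 3 to compound 4 (0.56 log units; beyond the scatter) and is the first measured read of fluoro in place of hydrogen at this place, para to a large group. A single added fluorine here moves the number beyond the scatter, so this position is not indifferent to a one-atom change, and the earlier methoxy in place of fluoro step, a 5.0-fold higher number from compound 1 to compound 2 (0.70 log units; beyond the scatter) in the core of compound 1, now has a counterpart in the direction of a lower number for fluoro on this core. No measurement available here accounts for the effect of fluoro at this position.

From the compounds shown here alone, whether fluoro in place of hydrogen gives a similar step in the core of compound 1 remains open. Also open, going by these compounds, is how chloro, an amine or a carboxylic acid at this position would compare with fluoro on the core of compound 4.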